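The compounds below may be only part of what the source reports. "The series", "measured", "known", "first", "only" and "open" are said of these compounds alone.

Compound 1 `Cc1[nH]n(-c2nc3ccccc3[nH]2)c(=O)c1Cc1ccccc1Cl` was tested in an assay on isolated protein for inhibition of alpha-ketoglutarate-dependent dioxygenase alkB homolog 3 (Homo sapiens), read by polymerase chain reaction, with a stated time of 1 h; a lower number here means a stronger inhibitor, a higher number a weaker inhibitor. In this assay compound 1 gives > 10000 nM, which is a limit of the assay rather than a measured number, so compound 1 stands at the limit of > 10000 nM in this assay, at which 1 of the 2 values shown sits. A second compound, compound 2 `Cc1ccc2[nH]c(-n3[nH]c(C)c(C)c3=O)nc2c1`, gives 2600 nM in this assay. Compound 3 `Cc1[nH]n(-c2nc3ccccc3[nH]2)c(=O)c1Cc1ccc(F)cc1` differs from compound 1 by 4-fluorophenyl in place of 2-chlorophenyl on a saturated chain carbon bound to an aromatic carbon. Going by the values given here, no pair of measured compounds shows this change, so its size is not known from the data, and no step beyond the usual scatter is expected in this assay. Compound 3 is expected to give 15000 nM, somewhere between 4000 nM and 50000 nM, an expected step that the limit leaves unreadable from compound 1 to compound 3.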

Compound 3, half-maximal inhibitory concentration: 600 nM
The estimate for compound 3 lay 25-fold (1.40 log units) above the measured number; the whole stated range lies above it.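

Among the compounds shown, only this change touches this position, and it shows that the group here strongly affects the result. In this assay, 4-fluorophenyl in place of 2-chlorophenyl gives an at least 16-fold lower number from compound 1 to compound 3 (1.22 log units; beyond the scatter). The value for compound 1 is a limit, so this step has no exact size: the limit of > 10000 nM in this assay, at which 1 of the 3 values shown sits.

Still open, going by these compounds, is whether the change of halogen or its place on the ring carries the step. On these data alone, how an unsubstituted benzyl group or a longer chain would read at this position also remains unknown.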